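The compounds below may be only part of what the source reports. "The series", "measured", "known", "first", "only" and "open" are said of these compounds alone.

Compound 1 `Cc1ccc2nc(-c3ccc(F)cc3)cc(C(=O)OCc3ccccc3)c2c1` and compound 2 `COc1ccc(-c2cc(C(=O)OCc3ccccc3)c3cc(C)ccc3n2)cc1` share one core. In a functional assay on HT-29 cells (Homo sapiens) for antiproliferative activity, read by MTT assay, with a stated time of 48 h (on this read-out higher numbers stand for weaker inhibition and lower numbers for stronger inhibition), compound 1 gives 15100 nM, and compound 2 gives 17300 nM. The step of a 1.1-fold higher number from compound 1 to compound 2 (0.06 log units; within the scatter) belongs to the change (methoxy in place of fluoro on an aromatic carbon).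

Compound 3 `Cc1ccc2nc(-c3ccc(F)cc3)cc(COCc3ccccc3)c2c1` carries a different core; how it differs from the core of compound 1 is not broken down here. In this assay compound 3 reaches only a limit, > 100000 nM, the same limit as the limit of > 100000 nM in this assay, at which 1 of the 3 values shown sits.

Compound 4 `COc1ccc(-c2cc(COCc3ccccc3)c3cc(C)ccc3n2)cc1` is not yet measured. It differs from compound 3 by methoxy in place of fluoro on an aromatic carbon, the same change that leads from compound 1 to compound 2. The expected step is therefore small, a step that the limit leaves unreadable from compound 3 to compound 4, resting on the small step of a 1.1-fold higher number from compound 1 to compound 2 (0.06 log units; within the scatter) seen with the other core. Since compound 3 sits at a limit, compound 4 is expected to give about 150000 nM, between 60000 nM and 400000 nM, most likely again as a limit.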

Compound 4, half-maximal inhibitory concentration: > 100000 nM
Compound 4 gave a limit, no number; the forecaster's own chance of this, stated with the estimate: 75%; the middle value does not contradict the limit.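

Compound 3 and compound 4 both stand only as limits in this assay, so no step can be read between them: the limit of > 100000 nM in this assay, at which 2 of the 4 values shown sit.

The compounds shown leave open what methoxy in place of fluoro does on the core of compound 3.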